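The source may report more compounds than this note shows. Statements on the series, on what has been measured and on what is new or still open speak of the compounds shown alone.

Of the compounds shown here, three have so far been tested in a functional assay for inhibition, with Homo sapiens as the target; a higher number here means a weaker inhibitor, a lower number a stronger inhibitor. Compound 1 `CCCc1nc(C)c2c(C)nn(C)c(=O)n12` gives > 48000 nM in this assay, which is a limit of the assay and not a number. Compound 2 `CCCc1nc(C)c2c(C)nn(CCC)c(=O)n12` likewise gives > 48000 nM in this assay, again a limit. Among the compounds with values here, compound 3 `CCCc1nc(C)c2ccnc(Nc3cc[nH]n3)n12` gives 25000 nM in this assay, the only plain number among the three. Compound 2 and compound 1 differ by hydrogen in place of ethyl on a saturated chain carbon bound to an aromatic nitrogen, and a step that the two limits leave unreadable from compound 2 to compound 1, since (the limit of > 48000 nM in this assay, at which 2 of the 3 values shown sit). The difference between the core of compound 3 and the core of compound 2 is not broken down here.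

Compound 4 `Cc1nc(C)n2c(Nc3cc[nH]n3)nccc12` has not been measured; it differs from compound 3 by hydrogen in place of ethyl on a saturated chain carbon bound to an aromatic carbon. Within the data shown here, this is the same kind of change as the one from compound 2 to compound 1, but not the same: there the place was on a saturated chain carbon bound to an aromatic nitrogen, here it is on a saturated chain carbon bound to an aromatic carbon. Beside that unreadable earlier step, compound 4 is expected to move by a 1.4-fold higher number from compound 3 to compound 4 (0.15 log units; within the scatter), a small step. Among the measured compounds shown here, that expectation rests on compound 3 at 25000 nM alone, as no measured step for this change is readable. Compound 4 is therefore estimated at 35000 nM, between 10000 nM and 100000 nM.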

Compound 4, half-maximal inhibitory concentration: 53000 nM
Compound 4: the middle estimate sits 1.5-fold (0.18 log units) below what was measured, within the range that was stated.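

Going from propyl to methyl on a saturated chain carbon bound to an aromatic carbon gives a 2.1-fold higher number from compound 3 to compound 4 (0.33 log units; beyond the scatter) in this assay, so on this core the shorter chain goes with a weaker inhibitor. The same kind of change on the other core, going from compound 2 to compound 1, cannot be read, as both compounds sit at a limit of the assay and not at a number: the limit of > 48000 nM in this assay, at which 2 of the 4 values shown sit. The result therefore rests on a single pair on a single core, and it does not show whether the change carries over from one core to another, where the place also differs, being a saturated chain carbon bound to an aromatic nitrogen on the other core.

The compounds shown leave open how a chain longer than propyl, an amine or a carboxylic acid would read at this place on the core of compound 3. They also leave open whether any chain on the core of compound 1 would give a plain number rather than a limit.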